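Nitro in place of methyl, from compound 3 to compound 4

This account rests on a few compounds, and the source may have more. Where it says the series, first, only, none or still open, it means among the compounds named here.

In a functional assay on the whole organism with Rattus norvegicus as the target (on this read-out higher numbers stand for an effect only at larger amounts of compound and lower numbers for an effect already at smaller amounts), compound 3 (`CCOC(=O)C(=O)Nc1cccc(C)c1C#N`) stands highest of three numbers, at 4.6 mg/kg against compound 2 (`CCOC(=O)C(=O)Nc1cccc(N(C)C(C)C)c1C#N`) at 1.2 mg/kg and compound 1 (`CCOC(=O)C(=O)Nc1cccc(NC)c1C#N`) at 0.1 mg/kg in the same series. Compound 4 (`CCOC(=O)C(=O)Nc1cccc([N+](=O)[O-])c1C#N`) carries nitro in place of methyl on an aromatic carbon, ortho to a cyano group (nitro in place of methyl on an aromatic carbon). The two measured steps at this carbon (a 46-fold higher number from compound 1 to compound 3 (1.66 log units; beyond the scatter) and a 3.8-fold higher number from compound 2 to compound 3 (0.58 log units; beyond the scatter)) both put methyl in place of an amino group, one large and one modest. Neither involves nitro, so they give no direct guide to size. A slightly lower number, with no step beyond the scatter, is expected (a 1.5-fold lower number from compound 3 to compound 4 (0.19 log units; within the scatter)). For compound 4 the estimated value is 3 mg/kg (expected range 0.6 mg/kg to 12 mg/kg).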

Compound 4, dose for half-maximal effect: 82 mg/kg
Estimate against measurement, compound 4: 27-fold (1.44 log units) below; measured number outside the range, above it.
By their numbers in this assay, from the lowest: compound 1; then compound 2; then compound 3; then compound 4.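

Nitro at this aromatic carbon extends the range already seen there in this assay (an 18-fold higher number from compound 3 to compound 4 (1.25 log units; beyond the scatter); a 68-fold higher number from compound 2 to compound 4 (1.83 log units; beyond the scatter); an 820-fold higher number from compound 1 to compound 4 (2.91 log units; beyond the scatter)), and compound 4 has the highest number of the four. The position therefore responds to an exchange between methyl and nitro, neither of which is an amino group, and not only to the loss of an amino group. Nothing at hand explains this change. From the compounds shown here alone, whether chlorine, a methoxy group or a primary amine at this carbon would lie closer to compound 1 or to compound 4 remains open.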